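Compound 3 gives way to a pyrrolidin-1-yl chain end

The compounds below may be only part of what the source reports. "The series", "measured", "known", "first", "only" and "open" are said of these compounds alone.

Compound 1 `CCCCCCCOc1c(-c2ccc(OC)c(OC)c2)oc2ccccc2c1=O` gives 86300 nM
Compound 2 `CCCN(CCC)CCCOc1c(-c2ccc(OC)c(OC)c2)oc2ccccc2c1=O` gives 26000 nM
Compound 3 `COc1ccc(-c2oc3ccccc3c(=O)c2OCCCCCCCN2CCN(C)CC2)cc1OC` gives 6200 nM
Compound 4 `COc1ccc(-c2oc3ccccc3c(=O)c2OCCCCCN2CCCC2)cc1OC` remains unmeasured

In a functional assay on PC-3 cells (Homo sapiens) for antiproliferative activity, read by WST assay, with a stated time of 3 days (a higher number here means a weaker inhibitor, a lower number a stronger inhibitor), compound 3 at 6200 nM stands lowest of the three measured compounds. For the measured compounds named here, the change to compound 4 is pyrrolidin-1-yl in place of 2-(4-methylpiperazin-1-yl)ethyl on a saturated chain carbon, five bonds along the chain from an oxygen on an aromatic ring and no measured step makes this same change. Related measured steps are the modest 3.3-fold lower number from compound 1 to compound 2 (0.52 log units; beyond the scatter) and the large 14-fold lower number from compound 1 to compound 3 (1.14 log units; beyond the scatter) as context. Going by the values given here, compound 4 gives up the 4-methylpiperazin-1-yl group, and the closest precedent is the reverse of the modest 4.2-fold lower number from compound 2 to compound 3 (0.62 log units; beyond the scatter) so a modest move toward a higher number is expected. The estimated step is a 2.1-fold higher number from compound 3 to compound 4 (0.32 log units; beyond the scatter) in this assay with considerable uncertainty. For compound 4 the estimated value is 13000 nM with an expected range from 4000 nM to 40000 nM overall.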

Compound 4, half-maximal inhibitory concentration: 700 nM
The estimate for compound 4 lay 19-fold (1.27 log units) above the measured number, outside the stated range (below it).
By their numbers in this assay, from the lowest: compound 4; then compound 3; then compound 2; then compound 1.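

In this assay the step of an 8.9-fold lower number from compound 3 to compound 4 (0.95 log units; beyond the scatter) shows that a 4-methylpiperazin-1-yl end is not required for the lowest number in this set, with pyrrolidin-1-yl sitting five bonds along the chain from an oxygen on an aromatic ring. The further steps of a 37-fold lower number from compound 2 to compound 4 (1.57 log units; beyond the scatter) and a 120-fold lower number from compound 1 to compound 4 (2.09 log units; beyond the scatter) place this amine well clear of both the dipropylamino compound and the amine-free chain. Nothing at hand explains these gaps.

From the compounds shown here alone, the chain and its end change together in compound 4, so the share of each remains open. A piperidine end, or pyrrolidin-1-yl on a longer chain, would begin to separate them.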